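A few compounds are considered here, and "the series" means these few. Any claim that something is new, unique, unknown or untested is made for them only; others in the source may bear on it.

Compound 1 `CC(=O)OC(CCCN1CCN(c2ncc(F)cn2)CC1)c1ccc(F)cc1` is tested in an assay (Cavia porcellus) for displacement of a labelled ligand from Sigma non-opioid intracellular receptor 1 (Homo sapiens) (a lower number here means a stronger inhibitor, a higher number a weaker inhibitor), where compound 1 gives 227 nM. Compound 2 `Fc1ccc(OCCCN2CCN(c3ncc(F)cn3)CC2)cc1` gives 89 nM in this assay. For compound 3 `O=S(=O)(CCCN1CCN(c2ncc(F)cn2)CC1)c1ccc(F)cc1` this assay reports only a limit, > 45 nM, rather than a number. Among the two numbers shown, compound 1 stands highest, with compound 2 nearest, and that gap lies beyond the usual scatter. The untested compound 4 `O=C(NC(CCCN1CCN(c2ncc(F)cn2)CC1)c1ccc(F)cc1)c1ccc(F)cc1` keeps the shared core of compound 1 and differs in one place: ((4-fluorophenyl)carbonyl)amino in place of acetoxy on a saturated chain carbon bound to an aromatic carbon and a saturated chain carbon. For the measured compounds named here, no measured pair here mirrors this change, so the step is judged from the change alone; a modest drop in the number is expected, so that the step of a 3.2-fold lower number from compound 1 to compound 4 (0.51 log units; beyond the scatter) is expected to go toward stronger binding. For compound 4 an estimate of 70 nM is given, expected to fall between 18 nM and 280 nM.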

Compound 4, half-maximal inhibitory concentration: > 100 nM
Compound 4 gave a limit, no number; the forecaster's own chance of this, stated with the estimate: 10%; middle value at least 1.4-fold (0.15 log units) away from the limit.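

Compound 4 gives only a limit, > 100 nM, not a number, so the step from compound 1 to compound 4 cannot be read. The compounds shown leave open whether ((4-fluorophenyl)carbonyl)amino in place of acetoxy gives stronger or weaker binding.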